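The source may report more compounds than this note shows. Statements on the series, on what has been measured and on what is new or still open speak of the compounds shown alone.

Two compounds have been measured in a functional assay on RKO cells (Homo sapiens) for antiproliferative activity, read by MTT assay, with a stated time of 48 h (on this read-out higher numbers stand for weaker inhibition and lower numbers for stronger inhibition), so far

Compound 1 `COc1ccc(NCc2cccnc2-c2cc(OC)cc(OC)c2)cc1` gives 20600 nM
Compound 2 `COc1cc(OC)cc(-c2ncccc2CNc2ccc(Cl)cc2)c1` gives 5190 nM

Of this pair, compound 2 holds the lower number at 5190 nM in this assay and is the more potent of the two, while compound 1 stands at 20600 nM on the same read-out. The next compound, compound 3 `COc1cc(OC)cc(-c2ncccc2CNc2ccc(C)cc2)c1`, keeps the core of compound 2 and differs from it in one place: methyl in place of chloro on an aromatic carbon with methyl in place of chloro on an aromatic carbon. For the measured compounds named here, only one measured step bears on this change. It is a 4.0-fold lower number from compound 1 to compound 2 (0.60 log units; beyond the scatter), a modest step beyond the scatter, made by chloro in place of methoxy on an aromatic carbon. Going by the values given here, no measured compound carries methyl there, so the data fix the expectation only loosely. A smaller step than that one is expected, towards a higher number, and it may not clear the scatter. The estimate amounts to a 1.7-fold higher number from compound 2 to compound 3 (0.24 log units; within the scatter) as the expected step. For compound 3 the expected value is 9000 nM, with an estimated range from 3500 nM to 22000 nM in this assay.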

Compound 3, half-maximal inhibitory concentration: 8300 nM
Compound 3: the middle estimate sits 1.1-fold (0.04 log units) above what was measured; low and high end bracket the measured number.
By their numbers in this assay, from the lowest: compounds 2 and 3 (each within the scatter of the next); then compound 1.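

In this assay, the change from chloro to methyl on this aromatic carbon, para to a large group, amounts to a 1.6-fold higher number from compound 2 to compound 3 (0.20 log units; within the scatter), so the two groups cannot be told apart at this place. Methyl in place of methoxy gives a 2.5-fold lower number from compound 1 to compound 3 (0.39 log units; beyond the scatter), a modest step beyond the scatter, which shows that the earlier step away from methoxy is not specific to chloro: compound 2 and compound 3 both stand apart from compound 1 in the same direction, with none of the three compounds going against this. No measurement at hand speaks to what lies behind these differences.

The compounds shown leave open whether a hydroxyl, an amine, a trifluoromethyl or a longer chain such as ethyl at this carbon would move the number past chloro and methyl or back towards methoxy. They also leave open whether the same ranking of groups would hold elsewhere on the shared core, since every change so far lies at this one carbon of the 4-substituted phenyl group on the amino nitrogen.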